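The source may report more compounds than this note shows. Statements on the series, on what has been measured and on what is new or still open speak of the compounds shown alone.

Compound 3, with the structure `CC1CC/C(=N\Nc2ccccc2F)c2ncc(C(=O)O)c(=O)n21`, is the starting point here. In a functional assay on the whole organism for inhibition, with Rattus norvegicus as the target (a lower number here means that less compound is needed, a higher number that more compound is needed for the effect), compound 3 gives 5 umol/kg, the lowest of the two single numbers in hand. The nearest comparison is compound 1, structure `CC1CC/C(=N\Nc2ccccc2)c2ncc(CC(=O)O)c(=O)n21`, which in this assay gives 100 umol/kg, a far higher number and well beyond the usual scatter. Compound 2, structure `C[C@H]1CCC(=NNc2ccccc2)c2ncc(C(=O)O)c(=O)n21`, has been measured twice in this assay and the two entries, 0.3 umol/kg; 54.8 umol/kg (2 entries), disagree widely; the spread seen in the several entries of compound 2 in this assay, 0.3 umol/kg; 54.8 umol/kg (2 entries) is a warning that a single number from this assay can move a long way on repetition.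

Compound 4, structure `CC1CC/C(=N\Nc2cccc(Br)c2)c2ncc(C(=O)O)c(=O)n21`, has not yet been measured. It differs from compound 3 in one place: 3-bromophenyl in place of 2-fluorophenyl on an amine nitrogen. Within the data shown here, no pair of measured compounds shows what such a swap on this amine nitrogen does, so there is nothing in hand to push the expectation strongly either way. The expected step of a 1.6-fold higher number from compound 3 to compound 4 (0.20 log units; within the scatter) is therefore small, not beyond the scatter. Compound 4 is estimated at 8 umol/kg in this assay, with a range from 2 umol/kg to 40 umol/kg.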

Compound 4, dose for 50% inhibition: 0.4 umol/kg
Compound 4: the middle estimate sits 20-fold (1.30 log units) above what was measured; the whole stated range lies above it.
By their numbers in this assay, from the lowest: compound 4; then compound 3; then compound 1.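

Among these compounds, the group on this amine nitrogen is the first place where a single change can be read, and it clearly matters in this assay: a 13-fold lower number from compound 3 to compound 4 (1.10 log units; beyond the scatter). The 2-fluorophenyl and 3-bromophenyl groups have the same count of heavy atoms and neither carries a hydrogen-bond donor or acceptor, yet the swap still moves the dose well beyond the scatter. The step rests on one entry for each compound, and repeated entries in this assay can differ widely: the several entries of compound 2 in this assay, 0.3 umol/kg; 54.8 umol/kg (2 entries)

Going by these compounds, whether the lower number follows from the bromine or from where it sits on the ring stays open, and 3-fluorophenyl or 2-bromophenyl on the same nitrogen would separate the two. How far the trend extends to other groups here, such as 3-chlorophenyl or 3-methoxyphenyl, is also unknown.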